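Aryl thioether replacing benzylamine on a fused diamine core

The source may hold more compounds than are shown below. What is called first, only, known or untested is meant among the compounds shown, and "the series" means these compounds.

Measured compounds:
compound 1, `Nc1cc(N)c2nc(-c3ccccc3)c(Oc3ccc(F)cc3)nc2c1`, 16600 nM
compound 2, `Nc1cc(N)c2nc(-c3ccccc3)c(NCc3ccc(F)cc3)nc2c1`, 5890 nM

For the measured compounds named here, in a functional assay on TK-10 cells (Homo sapiens) for inhibition, read by sulforhodamine B assay, with a stated time of 48 h (a lower number here means a stronger inhibitor of growth, a higher number a weaker inhibitor of growth), compound 2 gives the lower of the two numbers so far, and compound 1 stands a 2.8-fold lower number from compound 1 to compound 2 (0.45 log units; beyond the scatter). Compound 3, `COc1ccc(Sc2nc3cc(N)cc(N)c3nc2-c2ccccc2)cc1`, has not yet been measured in this assay. It differs from compound 2 by (4-methoxyphenyl)sulfanyl in place of (4-fluorobenzyl)amino on an aromatic carbon. Going by the values given here, only one measured step bears on this change: the move from compound 1 to compound 2, a 2.8-fold lower number from compound 1 to compound 2 (0.45 log units; beyond the scatter), exchanged a 4-fluorophenoxy group for a (4-fluorobenzyl)amino group, a modest step beyond the scatter. Among the compounds with values here, compound 3 returns to a ring joined directly through a single heteroatom, as in compound 1, though with sulfur in place of oxygen and a methoxy in place of fluorine, for which no step is available. The expectation is therefore that compound 3 moves back toward compound 1, with a step of a 2.0-fold higher number from compound 2 to compound 3 (0.31 log units; beyond the scatter). Compound 3 is estimated at 12000 nM in this assay, within a range from 4000 nM to 36000 nM.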

Compound 3, concentration for 50% growth inhibition: 12900 nM
Compound 3: middle estimate off by 1.1-fold (0.03 log units), on the low side; low and high end bracket the measured number.
By their numbers in this assay, from the lowest: compound 2; then compounds 3 and 1 (each within the scatter of the next).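

In this assay, the (4-methoxyphenyl)sulfanyl group does not hold the level reached with the (4-fluorobenzyl)amino group at this aromatic carbon next to the ring nitrogen: the exchange gives a 2.2-fold higher number from compound 2 to compound 3 (0.34 log units; beyond the scatter), a modest step but one beyond the scatter. Set against the 4-fluorophenoxy group, the same group gives a 1.3-fold lower number from compound 1 to compound 3 (0.11 log units; within the scatter), so the values of compound 1 and compound 3 cannot be told apart, even though the two groups differ in both the linking atom and the substituent on the outer ring. Among these three compounds, only the (4-fluorobenzyl)amino group of compound 2 therefore stands apart at this position, and the sulfur and oxygen links give no separable result here.

From the compounds shown here alone, since sulfur and methoxy enter together in compound 3, their separate contributions remain open, and a (4-fluorophenyl)sulfanyl group would be the direct test of the linking atom. Going by these compounds, it is also open whether the nitrogen link or its extra methylene carbon goes with the change in compound 2, a question that a 4-fluoroanilino group would address. Nothing in the data shown accounts for these differences.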